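This account rests on a few compounds, and the source may have more. Where it says the series, first, only, none or still open, it means among the compounds named here.

Compound 1 `CCCn1c(=O)[nH]c2nc(-c3ccc(S(=O)(=O)N4CCN(c5ccc(F)cc5)CC4)cc3)[nH]c2c1=O` was tested in an assay on CHO cells for displacement of a labelled ligand from adenosine receptor A1 (Homo sapiens), read by scintillation counting, with a stated time of 90 min, in the presence of a further agent that is not named here; on this read-out lower numbers stand for stronger inhibition and higher numbers for weaker inhibition. In this assay compound 1 gives > 1000 nM, which is a limit of the assay rather than a measured number, standing at the limit of > 1000 nM in this assay, at which 1 of the 3 values shown sits. Two close relatives were measured alongside it. Compound 2 `CCCn1c(=O)[nH]c2nc(-c3ccc(S(=O)(=O)N4CCN(Cc5cccc(Br)c5)CC4)cc3)[nH]c2c1=O` gives 928 nM, and compound 3 `CCCn1c(=O)[nH]c2nc(-c3ccc(S(=O)(=O)N4CCN(Cc5ccc(Br)c(F)c5)CC4)cc3)[nH]c2c1=O` gives 326 nM. Together these produce the steps of an at least 1.0-fold lower number from compound 1 to compound 2 (0.03 log units; that floor lies within the scatter), an at least 3.0-fold lower number from compound 1 to compound 3 (0.48 log units; beyond the scatter) and a 2.8-fold lower number from compound 2 to compound 3 (0.45 log units; beyond the scatter): the first stays within the scatter, while the second and third lie beyond it.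

The compound still to be measured is compound 4 `CCCn1c(=O)[nH]c2nc(-c3ccc(S(=O)(=O)N4CCN(c5ccc(I)cc5)CC4)cc3)[nH]c2c1=O`. It differs from compound 1 by iodo in place of fluoro on an aromatic carbon, that is, 4-fluorophenyl to 4-iodophenyl. None of the three measured steps makes this kind of change: each exchanges the whole group on the amine nitrogen in a ring, whereas here a single halogen on the 4-fluorophenyl is swapped for another. The measured steps therefore give no direct guide, and with compound 1 itself only a limit, the expectation is no step beyond the scatter. Compound 4 is accordingly estimated at 1500 nM, within a range from 500 nM to 5000 nM, which would mean an expected step that the limit leaves unreadable from compound 1 to compound 4.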

Compound 4, inhibition constant: > 1000 nM
Compound 4: a limit, no number; the forecaster's own chance of this, stated with the estimate: 60%; the middle value lies beyond the limit too.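

In this assay, compound 1 and compound 4 each give a limit and not a number, so the steps between them and the exchange of fluoro for iodo, para to a large group, cannot be read: the limit of > 1000 nM in this assay, at which 2 of the 4 values shown sit.

What is new is that iodo at this place does not bring the compound to a readable value, so both compounds with a 4-halophenyl group on the amine nitrogen, compound 1 and compound 4, stay at the limit, whereas the benzyl compounds, compound 2 and compound 3, give numbers. Against the benzyl compounds the picture is uneven: there is an at least 3.0-fold higher number from compound 3 to compound 4 (0.48 log units; beyond the scatter), while there is an at least 1.0-fold higher number from compound 2 to compound 4 (0.03 log units; that floor lies within the scatter), so only the 4-bromo-3-fluorobenzyl compound clearly separates from the new one.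

As far as these compounds go, how far compound 1 and compound 4 lie past the limit, and whether the halogen matters here at all, stays open. Also open, from the compounds shown here alone, is whether a 4-iodobenzyl group on the same nitrogen would give a readable number, and what a chloro or methoxy group would do in place of the halogen on the aromatic carbon.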